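Furan in place of thiophene on a shared nucleoside core

This account rests on a few compounds, and the source may have more. Where it says the series, first, only, none or still open, it means among the compounds named here.

Compound 1 `O=c1[nH]cnc2c1c(-c1ccoc1)cn2[C@@H]1O[C@H](CO)[C@@H](O)[C@H]1O` and compound 2 `O=c1[nH]cnc2c1c(-c1cccs1)cn2[C@@H]1O[C@H](CO)[C@@H](O)[C@H]1O` share one core and differ only by furan-3-yl in place of thiophen-2-yl on an aromatic carbon. In a functional assay on HL-60 cells (Homo sapiens) for antiproliferative activity, read by XTT assay, with a stated time of 72 h (a higher number here means a weaker inhibitor, a lower number a stronger inhibitor), compound 1 gives 6370 nM. For compound 2 the result is only a limit of the assay, > 20000 nM. The step is an at least 3.1-fold lower number from compound 2 to compound 1 (0.49 log units; beyond the scatter). Compound 3 `Nc1nc2c(c(-c3cccs3)cn2[C@@H]2O[C@H](CO)[C@@H](O)[C@H]2O)c(=O)[nH]1` has a different core, set apart from compound 2 by amino in place of hydrogen on an aromatic carbon. For compound 3 too the result is only a limit of the assay, > 20000 nM. The step that the two limits leave unreadable from compound 2 to compound 3 cannot be sized because of the limit of > 20000 nM in this assay, at which 2 of the 3 values shown sit. Compound 4 `Nc1nc2c(c(-c3ccoc3)cn2[C@@H]2O[C@H](CO)[C@@H](O)[C@H]2O)c(=O)[nH]1`, not yet measured, differs from compound 3 by furan-3-yl in place of thiophen-2-yl on an aromatic carbon, the same change as from compound 2 to compound 1. The expected step, an at least 2.2-fold lower number from compound 3 to compound 4 (0.34 log units; beyond the scatter), rests on the measured step of an at least 3.1-fold lower number from compound 2 to compound 1 (0.49 log units; beyond the scatter). The estimate for compound 4 is 9000 nM, with a real chance that only a limit is reported again.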

Compound 4, half-maximal inhibitory concentration: > 15000 nM
Compound 4: no number, only a limit; the forecaster's own chance of this, stated with the estimate: 35%; middle value at least 1.6-fold (0.22 log units) from the limit.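

In this assay compound 4 gives > 15000 nM, which is a limit of the assay and not a number. Compound 3 also stands at a limit, so the step between them cannot be read, nor can the step between compound 2 and compound 3; the swap of thiophen-2-yl for furan-3-yl is thus neither shown to carry over to the amino-bearing core nor shown to fail there. The one readable result is that amino in place of hydrogen on an aromatic carbon gives an at least 2.3-fold higher number from compound 1 to compound 4 (0.37 log units; beyond the scatter).

The compounds shown leave open how furan-2-yl or thiophen-3-yl would behave on either core. They also leave open what a methyl or methylamino group would do in place of the amino group.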